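Phenyl in place of naphthalen-2-yl in compound 3

The compounds below may be only part of what the source reports. "The series", "measured", "known", "first", "only" and "open" are said of these compounds alone.

Compound 2 `CCCSc1nc(N/N=C/c2ccc3ccccc3c2)c2nnn(Cc3ccccc3)c2n1` gives > 64000 nM in a functional assay on ECa-109 cells (Homo sapiens) for antiproliferative activity, read by MTT assay, with a stated time of 72 h (a lower number here means a stronger inhibitor, a higher number a weaker inhibitor), which is a limit of the assay rather than a number. Compound 1 `CCCSc1nc(N/N=C/c2ccccc2Cl)c2nnn(Cc3ccccc3)c2n1` gives 6180 nM in this assay, and the step of an at least 10-fold higher number from compound 1 to compound 2 (1.01 log units; beyond the scatter) runs into that limit (the limit of > 64000 nM in this assay, at which 1 of the 2 values shown sits). Compound 3 `CCCSc1nc(N/N=C/c2ccccc2)c2nnn(Cc3ccccc3)c2n1` differs from compound 2 by phenyl in place of naphthalen-2-yl on a carbon with a double bond to nitrogen. Going by the values given here, that single measured step, large and beyond the scatter, is the only guide, and it is being partly reversed in ring count, though phenyl was never compared with 2-chlorophenyl. Compound 3 is therefore expected near 15000 nM (range 4000 nM to 64000 nM), an estimated step of an at least 4.2-fold lower number from compound 2 to compound 3 (0.63 log units; beyond the scatter).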

Compound 3, half-maximal inhibitory concentration: > 64000 nM
Compound 3 ended at the assay's limit (the forecaster's own chance of this, stated with the estimate: 35%); at least 4.2-fold (0.63 log units) between middle value and limit.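

Hydrogen in place of chloro on an aromatic carbon gives an at least 10-fold higher number from compound 1 to compound 3 (1.01 log units; beyond the scatter), so the chloro of compound 1 counts on its own, and compound 1 is the only one of the three with a readable value in this assay. The step between compound 2 and compound 3 cannot be read, so phenyl and naphthalen-2-yl cannot be ranked, as both values are limits rather than numbers: the limit of > 64000 nM in this assay, at which 2 of the 3 values shown sit.

On these data alone, whether fluoro, methoxy or an amine in place of the chloro would keep a readable value stays open. So does how far compound 2 and compound 3 lie beyond the limit.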